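Working notes: isopropyl to tert-butyl in the series

The compounds below may be only part of what the source reports. "The series", "measured", "known", "first", "only" and "open" are said of these compounds alone.

Of the compounds shown here, two have numbers so far, both from a physicochemical assay for lipophilicity, measured as octanol-water partition; a higher number here means a more lipophilic compound, a lower number a more polar compound. Compound 1 (`CC(C)c1ccc(C[C@H](C)C(=O)N[C@@H]2O[C@H](CO)[C@@H](O)[C@H](O)[C@H]2O)cc1`) gives 0.143, the higher of the two. Compound 2 (`COc1ccc(/C=C/C(=O)N[C@@H]2O[C@H](CO)[C@@H](O)[C@H](O)[C@H]2O)c(O)c1`) gives -0.958, lower than compound 1 by more than the scatter. These two differ in more than one place, so their gap cannot be read as the size of any single change.

Compound 3 (`C[C@@H](Cc1ccc(C(C)(C)C)cc1)C(=O)N[C@@H]1O[C@H](CO)[C@@H](O)[C@H](O)[C@H]1O`) has not yet been measured. Its difference from compound 1 is methyl in place of hydrogen on a saturated chain carbon bound to an aromatic carbon and two saturated chain carbons, which reads as isopropyl to tert-butyl. Among the measured compounds shown here, no measured pair shows a single change, so the expectation rests on the structural change alone. A modest rise in this assay is expected, probably just past the scatter, though a step within it cannot be excluded. The estimated move is a number 0.41 log units higher from compound 1 to compound 3 (beyond the scatter). For compound 3 the estimated value is 0.55, with an expected range from 0.2 to 0.9.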

Compound 3, partition coefficient: 0.379
Beside the measured number, compound 3's estimate is 0.17 log units above it, within the range that was stated.
By their numbers in this assay, from the lowest: compound 2; then compounds 1 and 3 (each within the scatter of the next).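

Among the compounds shown here, this is the first single-change step the series offers: methyl in place of hydrogen on a saturated chain carbon bound to an aromatic carbon and two saturated chain carbons, which reads as isopropyl to tert-butyl, gives in this assay a number 0.24 log units higher from compound 1 to compound 3 (within the scatter) as its result. At this position, the one added carbon therefore leaves compound 1 and compound 3 unresolved from each other in this assay, and this single pair is all that the size of the change rests on so far. No independent data bear on why the step has this size.

On these data alone, whether another group on the same saturated chain carbon, such as a longer chain, an amine or a carboxylic acid, would give a step beyond the scatter remains open, as does whether the same methyl change would give a similar step on another part of the series. The gap to compound 2 spans more than one place, so it stays unassigned to any single change.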